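This account rests on a few compounds, and the source may have more. Where it says the series, first, only, none or still open, it means among the compounds named here.

Measured so far in a physicochemical assay for solubility, using the shake flask method, measured as kinetic solubility, with a stated time of 20 h, at pH 2; a higher number here means a more soluble compound, a lower number a less soluble compound:
- Compound 1 `FC(F)(F)c1ccc(Nc2cc3[nH]c(-c4cccc(C(F)(F)F)c4)nc3cn2)nc1`: < 5000 nM (a limit, not a number)
- Compound 2 `FC(F)(F)c1ccc(Nc2cc3[nH]c(C4CC4)nc3cn2)nc1`: 198000 nM

Among the compounds with values here, compound 2 gives 198000 nM, the only actual number so far in this assay. The one other result is a limit: the limit of < 5000 nM in this assay, at which 1 of the 2 values shown sits.

Next is compound 3 `CC1(c2nc3cnc(Nc4ccc(C(F)(F)F)cn4)cc3[nH]2)CC1`, with the change methyl in place of hydrogen on a saturated ring carbon, or cyclopropyl to 1-methylcyclopropyl.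

Within the data shown here, only one measured step bears on this. It is an at least 39-fold higher number from compound 1 to compound 2 (1.59 log units; beyond the scatter), with cyclopropyl in place of 3-(trifluoromethyl)phenyl on an aromatic carbon, a large step beyond the scatter. That step swaps a whole group at the place now being altered, and its size is only a bound since one end is a limit. The present change is far smaller, so a step of that size is not expected. The direction is taken from compound 1, where the larger group gave the lower reading, < 5000 nM, which is again a limit.

The expected change is a 1.7-fold lower number from compound 2 to compound 3 (0.22 log units; within the scatter), a modest drop that may stay within the scatter. For compound 3 the estimate is 120000 nM, with an expected range of 40000 nM to 250000 nM.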

Compound 3, solubility: 200000 nM
Estimate against measurement, compound 3: 1.7-fold (0.22 log units) below, within the range that was stated.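

In this assay, methyl in place of hydrogen on a saturated ring carbon of the three-membered ring is the first small change shown at this position, and it gives a 1.0-fold higher number from compound 2 to compound 3 (0.00 log units; within the scatter), so the readings for cyclopropyl and 1-methylcyclopropyl cannot be told apart. The contrast with 3-(trifluoromethyl)phenyl now rests on two compounds rather than one, with an at least 40-fold higher number from compound 1 to compound 3 (1.60 log units; beyond the scatter) standing alongside an at least 39-fold higher number from compound 1 to compound 2 (1.59 log units; beyond the scatter), and both steps lie beyond the scatter. Both are only bounds on the true size, and the result for compound 1 is a limit: the limit of < 5000 nM in this assay, at which 1 of the 3 values shown sits.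

Whether an amine or a longer chain at the same ring carbon would read like compound 3 remains open, since a single methyl is the only addition to the cyclopropyl ring shown here. Also open, going by these compounds, is where an unsubstituted phenyl would fall in this read-out, and so whether the large gap belongs to the aromatic ring itself or to its trifluoromethyl group.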